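The source may hold more compounds than are shown below. What is called first, only, known or untested is meant among the compounds shown, and "the series" means these compounds.

- Compound 1 `COc1cc(NCc2ccc(Cl)cc2)cc(OC)c1OC`: > 80000 nM
- Compound 2 `COc1cc(NCc2ccc(Br)cc2)cc(OC)c1OC`: > 80000 nM

Both entries come from a functional assay on HCT-116 cells (Homo sapiens) for inhibition, read by MTT assay, with a stated time of 48 h (a lower number here means a stronger inhibitor, a higher number a weaker inhibitor), and neither is a true number. Compound 2 stands at > 80000 nM, which is a limit of the assay. The same holds for compound 1, so the data sit at the limit of > 80000 nM in this assay, at which 2 of the 2 values shown sit.

Compound 3 `COc1cc(NCc2cccc(O)c2)cc(OC)c1OC` has 3-hydroxyphenyl in place of 4-bromophenyl on a saturated chain carbon bound to a nitrogen on an aromatic ring.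

Among the compounds with values here, the only measured step is a step that the two limits leave unreadable from compound 1 to compound 2. It swaps one halogen for another, has no readable size, and so offers little guidance for this larger change. The limit for compound 2 at > 80000 nM remains the main anchor for an expectation. The estimated step is an at least 1.1-fold lower number from compound 2 to compound 3 (0.05 log units; that floor lies within the scatter), and any movement in this assay is expected to be toward a lower number. Another limit would not be surprising. For compound 3 the estimated value is 70000 nM, with an expected range from 20000 nM to 160000 nM.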

Compound 3, half-maximal inhibitory concentration: 67700 nM
For compound 3 the middle estimate is 1.0-fold (0.01 log units) above the measured one; low and high end bracket the measured number.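

In this assay, within the data shown here, compound 3 gives 67700 nM, the first true number here, so this position on the saturated chain carbon now has a measured value. The change from a halogen-bearing phenyl to 3-hydroxyphenyl gives an at least 1.1-fold lower number from compound 2 to compound 3 (0.07 log units; that floor lies within the scatter), and the comparison with the chloro analogue gives an at least 1.1-fold lower number from compound 1 to compound 3 (0.07 log units; that floor lies within the scatter). Both are only floors, and the step between the two halogen compounds cannot be read: the limit of > 80000 nM in this assay, at which 2 of the 3 values shown sit.

This single change alters both the group on the ring and its place, so the compounds shown do not separate the hydroxyl group from its position. They also leave open how 3-aminophenyl or 3-carboxyphenyl at this same carbon would read in this assay.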